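Compound 2 to compound 3: a 1-hydroxycyclobutyl change

The compounds below may be only part of what the source reports. "The series", "measured", "known", "first", "only" and "open" are said of these compounds alone.

In a functional assay on the whole organism (strain C57BL/6J) with Mus musculus as the target, read by PET imaging, with stated times of 2 weeks and 14 days, at a dose of 300 mg/kg by the oral route (on this read-out higher numbers stand for weaker inhibition and lower numbers for stronger inhibition), compound 1 (`CCCOc1nc(OCC(C)(C)O)c(-c2ccc(S(C)(=O)=O)cc2)cc1CO`) gives 4400 nM and compound 2 (`CCCCOc1nc(OCC(C)(C)O)c(-c2ccc(S(C)(=O)=O)cc2)cc1CO`) gives 13000 nM as the higher of the two numbers. Within the data shown here, that gap is the only measured step, a 3.0-fold higher number from compound 1 to compound 2 (0.47 log units; beyond the scatter), which is modest and comes from methyl in place of hydrogen on a saturated chain carbon, three bonds along the chain from an oxygen on an aromatic ring.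

Compound 3 (`CCCCOc1nc(OCC2(O)CCC2)c(-c2ccc(S(C)(=O)=O)cc2)cc1CO`) has 1-hydroxycyclobutyl in place of 1-hydroxy-1-methylethyl on a saturated chain carbon bound to an oxygen on an aromatic ring. Among the measured compounds shown here, no measured step touches this group, so the step above bears on it only indirectly. In this assay a change no larger than that modest step is expected, most likely none beyond the scatter, with a slight lean toward a higher number. The expected step is a 1.2-fold higher number from compound 2 to compound 3 (0.06 log units; within the scatter) in this estimate. For compound 3 the estimated value is 15000 nM with an expected range of 6000 nM to 40000 nM in this assay.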

Compound 3, half-maximal inhibitory concentration: 5500 nM
For compound 3 the middle estimate is 2.7-fold (0.44 log units) above the measured one, and the stated range ends above it.
By their numbers in this assay, from the lowest: compounds 1 and 3 (each within the scatter of the next); then compound 2.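

In this assay, the change to the group on a saturated chain carbon bound to an oxygen on an aromatic ring gives a 2.4-fold lower number from compound 2 to compound 3 (0.37 log units; beyond the scatter), the first step measured at this position. The series therefore responds here to 1-hydroxycyclobutyl in place of 1-hydroxy-1-methylethyl, even though the hydroxyl count is unchanged and the entering group adds only the four-membered ring of carbon. The earlier 3.0-fold higher number from compound 1 to compound 2 (0.47 log units; beyond the scatter) runs in the opposite direction but lies at a different place on the core, so these two steps establish no shared trend, and nothing measured on these compounds accounts for the new step.

The compounds shown leave open whether the same change would have a similar effect on the core of compound 1. They also leave open how a 1-hydroxycyclopentyl group, or an amine in place of the hydroxyl, would read at this position.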